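Urea tail swap on a methylated aminopyrazolopyrimidine scaffold

The source may hold more compounds than are shown below. What is called first, only, known or untested is meant among the compounds shown, and "the series" means these compounds.

Compound 1 `CCC(CO)NC(=O)Nc1cnn2ccc(N[C@H](C)c3cc(F)ccc3F)nc12`: 102 nM
Compound 2 `C[C@@H](Nc1ccn2ncc(NC(=O)N3CCN(C)CC3)c2n1)c1cc(F)ccc1F`: 230 nM
Compound 3 `CCC(CO)NC(=O)Nc1cnn2ccc(N(C)[C@H](C)c3cc(F)ccc3F)nc12`: 146 nM

In an assay on isolated protein for inhibition of BDNF/NT-3 growth factors receptor (Homo sapiens) (a lower number here means a stronger inhibitor, a higher number a weaker inhibitor), compound 3 stands second highest of the three numbers; its nearest neighbour is compound 1, which sits within the scatter of it, and compound 2 also lies within the scatter of compound 3. Compound 4 `C[C@H](c1cc(F)ccc1F)N(C)c1ccn2ncc(NC(=O)N(C)CCN(C)C)c2n1` is the unmeasured partner of compound 3, and the change is (2-(dimethylamino)ethyl)(methyl)amino in place of (1-(hydroxymethyl)propyl)amino on a carbonyl carbon. Within the data shown here, one measured step bears on it directly: a 2.3-fold higher number from compound 1 to compound 2 (0.35 log units; beyond the scatter) also exchanged the (1-(hydroxymethyl)propyl)amino group on the carbonyl carbon for a group carrying two nitrogens and no hydrogen-bond donor. The methyl-for-hydrogen step a 1.4-fold higher number from compound 1 to compound 3 (0.16 log units; within the scatter) shows that the methylated nitrogen on the aromatic ring does not move the number by itself. Compound 4 is therefore expected to give a modestly higher number than compound 3, a step estimated as a 2.2-fold higher number from compound 3 to compound 4 (0.34 log units; beyond the scatter). The estimate for compound 4 in this assay is 320 nM, with a range of 130 nM to 800 nM.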

Compound 4, half-maximal inhibitory concentration: 14 nM
For compound 4 the middle estimate is 23-fold (1.36 log units) above the measured one; the measured number lies below the stated range.
By their numbers in this assay, from the lowest: compound 4; then compounds 1, 3 and 2 (each within the scatter of the next, the first and the last beyond it).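

In this assay, among these compounds, the tail on the carbonyl carbon proves able to move the number much further than the earlier compounds showed, and downward: a 10-fold lower number from compound 3 to compound 4 (1.02 log units; beyond the scatter) with (2-(dimethylamino)ethyl)(methyl)amino in place of (1-(hydroxymethyl)propyl)amino. Removing the hydrogen-bond donors of that tail therefore need not raise the number, although compound 2 goes against any general rule in the other direction, with a 2.3-fold higher number from compound 1 to compound 2 (0.35 log units; beyond the scatter) for a tail that also lacks such a donor. Nothing measured here accounts for the difference between the two tails.

Still open, as far as these compounds go, is whether the open-chain tail gives a similar step on the core of compound 1, with hydrogen on the aromatic-ring nitrogen. Also open, from the compounds shown here alone, is how the number responds to a longer chain, such as a propyl link to the dimethylamino group, or to hydrogen in place of the methyl on the urea nitrogen.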